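Phenyl to 3-chlorophenyl on compound 2

The compounds below may be only part of what the source reports. "The series", "measured", "known", "first", "only" and "open" are said of these compounds alone.

In a functional assay on A549 cells (Homo sapiens) for antiproliferative activity, read by sulforhodamine B assay, with a stated time of 48 h (on this read-out lower numbers stand for stronger inhibition of growth and higher numbers for weaker inhibition of growth), compound 1 (`COc1cc(-c2nnc(C3=C(Cl)c4ccccc4CCC3)o2)cc(OC)c1OC`) gives 4570 nM while compound 2 (`Cc1cc2c(cc1C)C(Cl)=C(c1nnc(-c3ccccc3)o1)CCC2`) gives 1960 nM as the lower of the two numbers, a gap beyond the usual scatter. These two compounds differ in more than one place, so their gap cannot be tied to any single change.

Compound 3 (`Cc1cc2c(cc1C)C(Cl)=C(c1nnc(-c3cccc(Cl)c3)o1)CCC2`) departs from compound 2 in one place, phenyl to 3-chlorophenyl (chloro in place of hydrogen on an aromatic carbon), with chloro in place of hydrogen on an aromatic carbon. Among the compounds with values here, no measured pair shows this change, so this assay offers no direct guide and the expectation starts from compound 2 at 1960 nM as its anchor. The estimated step (a 1.3-fold lower number from compound 2 to compound 3 (0.12 log units; within the scatter)) is small, with no shift beyond the scatter expected. Compound 3 is estimated at 1500 nM with an expected range of 600 nM to 3800 nM in this read-out.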

Compound 3, concentration for 50% growth inhibition: 1970 nM
Compound 3: middle estimate off by 1.3-fold (0.12 log units), on the low side, and the stated range covers the measured number.
By their numbers in this assay, from the lowest: compounds 2 and 3 (each within the scatter of the next); then compound 1.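

In this assay, within the data shown here, the single change of phenyl to 3-chlorophenyl gives a 1.0-fold higher number from compound 2 to compound 3 (0.00 log units; within the scatter), the first step that can be tied to one place. Chloro in place of hydrogen at this place, meta to a large group, therefore brings no shift beyond the scatter, at least on the core shared by compound 2 and compound 3. No measurement shown here bears on the reason for this result.

From the compounds shown here alone, an amine or a carboxylic acid in place of the chloro remains open, since one substituent at one place does not define what this position tolerates. Also open, going by these compounds, is whether the same exchange would give a similar step on the core of compound 1, which differs from compound 2 in more than one place.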